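One ring stereocentre inverted: compound 3 to compound 4

The compounds below may be only part of what the source reports. "The series", "measured", "known", "first", "only" and "open" are said of these compounds alone.

Values measured in a functional assay on MCF7 cells (Homo sapiens) for antiproliferative activity, read by CellTiter-Glo, with a stated time of 5 days; a higher number here means a weaker inhibitor, a lower number a stronger inhibitor:
- compound 1 `CC1=C(c2cccc(O)c2)C(c2ccc(OC[C@H](C)N3CCCCC3)cc2)Oc2ccc(O)cc21`: 0.1 nM
- compound 2 `CC1=C(c2cccc(O)c2)[C@H](c2ccc(OC[C@H](C)N3CC[C@@H](C)C3)cc2)Oc2ccc(O)cc21`: 0.1 nM
- compound 3 `CC1=C(c2cccc(O)c2)C(c2ccc(OC[C@@H](C)N3CC[C@H](C)C3)cc2)Oc2ccc(O)cc21`: 0.2 nM

In this assay, compound 3, at 0.2 nM, stands within the scatter of both other compounds. The next compound to be tested is compound 4 `CC1=C(c2cccc(O)c2)C(c2ccc(OC[C@@H](C)N3CC[C@@H](C)C3)cc2)Oc2ccc(O)cc21`, and the change that leads to it is the two compounds have the same atoms and bonds; at least one stereo element is drawn with a configuration in one of them and without one in the other: 1 of 3 stereo elements differ; a stereocentre at a saturated ring carbon is drawn S in compound 3 and R in compound 4. Nothing enters or leaves, so only the drawn configuration at that ring carbon separates the two.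

Within the data shown here, two measured steps bear on this change. The closer in kind is a 2.0-fold higher number from compound 2 to compound 3 (0.30 log units; within the scatter), which also involves stereochemistry, including that of the ring carbon. It is only an imperfect guide because of the fact that one of compounds 2 and 3 is drawn with a defined configuration and the other without, at the place where they differ, and it changes more than one stereo element at once. The other is a 2.0-fold higher number from compound 1 to compound 3 (0.30 log units; within the scatter), which replaces the six-membered ring with the five-membered ring and likewise stays within the scatter.

Since neither of these steps moves the value beyond the scatter, no step beyond the scatter is expected here, in either direction. The expected change is no change at the digits printed from compound 3 to compound 4 (within the scatter). Compound 4 is estimated at 0.2 nM, with an expected range of 0.07 nM to 0.6 nM.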

Compound 4, half-maximal inhibitory concentration: 0.2 nM
Compound 4: the middle estimate sits on the measured number at the digits printed; the measured number falls inside the stated range.
By their numbers in this assay, from the lowest: compounds 1, 2, 3 and 4 (each within the scatter of the next).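

In this assay, among these compounds, the change of the drawn configuration at the saturated ring carbon, taken on its own, gives no change at the digits printed from compound 3 to compound 4 (within the scatter); the earlier stereo step had altered several stereo elements together, so this is the first comparison confined to this one centre. Compound 4 also lies within the scatter of the two other compounds, with a 2.0-fold higher number from compound 2 to compound 4 (0.30 log units; within the scatter) and a 2.0-fold higher number from compound 1 to compound 4 (0.30 log units; within the scatter), so in this small set neither drawn configuration at the ring carbon sets compound 4 apart, and the five-membered ring of compound 4 does not set it apart from the six-membered ring of compound 1. The step from compound 2 is the harder of these to interpret, as it changes two stereo elements and carries a further limit: the fact that one of compounds 2 and 4 is drawn with a defined configuration and the other without, at the place where they differ.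

How far the single-centre comparison can be taken as a clean one stays uncertain: the fact that one of compounds 3 and 4 is drawn with a defined configuration and the other without, at the place where they differ. The compounds shown also leave open what would follow if the methyl on the five-membered ring gave way to an ethyl or a hydroxyl, or if that ring gave way to a morpholine.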